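A Pyridinylmethyl Group in Place of Ethyl

This account rests on a few compounds, and the source may have more. Where it says the series, first, only, none or still open, it means among the compounds named here.

Of the compounds shown here, three have been measured in a physicochemical assay for solubility; on this read-out higher numbers stand for higher solubility and lower numbers for lower solubility. Compound 1, `CNC(=O)c1ccc(-c2ccc3c(c2)C(C)(C)C(=O)N3c2ccc(C#N)c(OC)c2)cc1F`, gives 9700 nM in this assay. Compound 2, `N#Cc1ncc(-n2c(=O)n(Cc3ccccc3)c3ccccc32)cc1C(F)(F)F`, gives 5300 nM. Compound 3, `CCn1c(=O)n(-c2ccc(C#N)c(C(F)(F)F)c2)c2ccccc21`, gives 3470 nM, the lowest of the three numbers; its gap to compound 2 lies within the scatter, while its gap to compound 1 lies beyond it.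

Compound 4, `N#Cc1ccc(-n2c(=O)n(Cc3cccnc3)c3ccccc32)cc1C(F)(F)F`, has not yet been measured. It differs from compound 3 in one place: pyridin-3-yl in place of methyl on a saturated chain carbon bound to an aromatic nitrogen. For the measured compounds named here, no measured pair shows this exact change, so the size of the step can only be guessed. The change adds one aromatic ring and one hydrogen-bond acceptor, and compound 2, which also carries an arylmethyl group, gives 5300 nM, a number within the scatter of compound 3.

Compound 4 is therefore expected to show a modest upward step, a 1.7-fold higher number from compound 3 to compound 4 (0.24 log units; within the scatter), that may well stay within the scatter. The estimated solubility of compound 4 is 6000 nM, with a range from 2500 nM to 15000 nM.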

Compound 4, solubility: 2500 nM
Compound 4: middle estimate off by 2.4-fold (0.38 log units), on the high side; low and high end bracket the measured number.
By their numbers in this assay, from the lowest: compounds 4, 3, 2 and 1 (each within the scatter of the next, the first and the last beyond it).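

In this assay, pyridin-3-yl in place of methyl on a saturated chain carbon bound to an aromatic nitrogen gives a 1.4-fold lower number from compound 3 to compound 4 (0.14 log units; within the scatter). For the compounds shown here, this is the first pair here that differs in one place, and it shows that this position can carry a six-membered aromatic ring and a hydrogen-bond acceptor with a step that stays within the scatter. Nothing measured here explains this result.

Compound 2 differs from compound 4 in more than one place, so it cannot show what the ring nitrogen of pyridin-3-yl contributes on its own. Also open, on these data alone, is how a chain ending in an amine or a carboxylic acid would read at this position.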